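Trifluoromethyl on the distal phenyl: cytotoxicity outlook

The source may hold more compounds than are shown below. What is called first, only, known or untested is meant among the compounds shown, and "the series" means these compounds.

Three compounds of the series share a core and a basic side chain and differ only at the para substituent of the benzyl arm. Compound 1 `Cc1c(Cc2ccc(Cl)cc2)c(=O)oc2cc(OCC(O)CN3CCC(C(N)=O)CC3)ccc12` carries chloro; in an ADME assay on A549 cells (Homo sapiens) for cytotoxicity, read by CellTiter-Glo (on this read-out lower numbers stand for higher toxicity in this test and higher numbers for lower toxicity in this test), compound 1 gives 40000 nM. Compound 2 `Cc1noc(C)c1-c1ccc(Cc2c(C)c3ccc(OCC(O)CN4CCC(C(N)=O)CC4)cc3oc2=O)cc1` carries 3,5-dimethyl-1,2-oxazol-4-yl and in this assay compound 2 gives 36900 nM, a change of a 1.1-fold lower number from compound 1 to compound 2 (0.04 log units; within the scatter). Compound 3 `Cc1c(Cc2ccc(-c3ccccc3)cc2)c(=O)oc2cc(OCC(O)CN3CCC(C(N)=O)CC3)ccc12` carries phenyl. For compound 3 this assay reports only a limit, > 100000 nM, so the true number for compound 3 is not known. The steps to compound 3 both read as beyond the scatter: an at least 2.5-fold higher number from compound 1 to compound 3 (0.39 log units; beyond the scatter) and an at least 2.7-fold higher number from compound 2 to compound 3 (0.43 log units; beyond the scatter), the size of each being bounded by the limit of > 100000 nM in this assay, at which 1 of the 3 values shown sits.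

Compound 4 `Cc1c(Cc2ccc(-c3ccc(C(F)(F)F)cc3)cc2)c(=O)oc2cc(OCC(O)CN3CCC(C(N)=O)CC3)ccc12` is the next member. Its change from compound 3 is trifluoromethyl in place of hydrogen on an aromatic carbon. Going by the values given here, no measured step shows the same change; the closest evidence is that compound 3 already sits at the limit and that both enlargements of the para group have moved the number up rather than down. A step within the scatter is therefore expected, a step that the limit leaves unreadable from compound 3 to compound 4, with the number likely again reported only as a limit. For compound 4 in this assay the estimate is 120000 nM, expected to fall between 40000 nM and 360000 nM.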

Compound 4, half-maximal cytotoxic concentration: > 100000 nM
Compound 4: a limit, no number (the forecaster's own chance of this, stated with the estimate: 65%); the middle value does not contradict the limit.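

In this assay compound 4 gives > 100000 nM, a limit and not a number. The position para to a large group therefore tolerates trifluoromethyl on the added phenyl without the read-out returning to the range of the chloro and 3,5-dimethyl-1,2-oxazol-4-yl compounds, as shown by an at least 2.5-fold higher number from compound 1 to compound 4 (0.39 log units; beyond the scatter) and by an at least 2.7-fold higher number from compound 2 to compound 4 (0.43 log units; beyond the scatter). The step from compound 3 to compound 4 cannot be read, so this change has no measurable size here, and the series now has a second compound without a number: the limit of > 100000 nM in this assay, at which 2 of the 4 values shown sit.

Going by these compounds alone, still open is whether an amine or a carboxylic acid in place of trifluoromethyl on the same ring would bring the read-out back under the limit, which would show whether this phenyl tolerates substitution generally or only with the one group tested. Also open, as far as these compounds go, is how far compound 3 and compound 4 each lie past the limit, and so whether they differ at all in this test; only a wider concentration range could settle that.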